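The source may hold more compounds than are shown below. What is called first, only, known or untested is meant among the compounds shown, and "the series" means these compounds.

Series in a functional assay on HepG2 cells (Homo sapiens) for cytotoxicity, read by MTT assay, with a stated time of 48 h; on this read-out higher numbers stand for weaker inhibition and lower numbers for stronger inhibition:
- Compound 1 `Cc1nnc(SCc2ccccc2)n1N1C(=O)c2ccccc2C1=O`; in this assay compound 1 gives > 200000 nM, a limit of the assay.
- Compound 2 `CCc1nnc(SCc2ccccc2)n1N1C(=O)c2ccccc2C1=O`; in this assay compound 2 gives > 200000 nM, a limit of the assay.
- Compound 3 `C=CCSc1nnc(CCC)n1N1C(=O)c2ccccc2C1=O`; in this assay compound 3 gives > 200000 nM, a limit of the assay.

Every value shown sits at the limit of > 200000 nM in this assay, at which 3 of the 3 values shown sit, so no number exists for any of the three. Compound 3 therefore stands at the limit only, and the two further values are limits as well. For the measured compounds named here, the single one-place step, a step that the two limits leave unreadable from compound 1 to compound 2, cannot be read because both of its ends sit at the limit of > 200000 nM in this assay, at which 3 of the 3 values shown sit.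

Compound 4 `CCCc1nnc(SCc2ccccc2)n1N1C(=O)c2ccccc2C1=O` differs from compound 3 by phenyl in place of vinyl on a saturated chain carbon bound to a sulfur. Going by the values given here, no measured step bears on this change: the only step in hand concerns the other substituent of the core and is itself unreadable. The shift from compound 3 to compound 4 is expected to be a step that the limit leaves unreadable from compound 3 to compound 4, with no movement beyond the scatter supported by anything shown. Compound 4 is expected to give 300000 nM in this assay, with a range from 120000 nM to 1500000 nM, and most likely another limit rather than a number.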

Compound 4, half-maximal inhibitory concentration: > 200000 nM
Compound 4: no number, only a limit (the forecaster's own chance of this, stated with the estimate: 85%); the middle value does not contradict the limit.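

Compound 4 also gives only a limit of the assay, so its steps from compound 1, compound 2 and compound 3 cannot be read: the limit of > 200000 nM in this assay, at which 4 of the 4 values shown sit.

The compounds shown leave open whether, in this assay, any change on the shared core gives a number rather than a limit.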